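A few compounds are considered here, and "the series" means these few. Any claim that something is new, unique, unknown or untested is made for them only; others in the source may bear on it.

In a functional assay on MCF7 cells (Homo sapiens) for cytotoxicity, read by sulforhodamine B assay (a lower number here means that less compound is tolerated, a higher number that more compound is tolerated), compound 1 `CC1=CC[C@@H]([C@@](C)(O)CCCC(C)(C)NC=S)CC1` gives only a limit, > 100000 nM, and no number. Compound 2 `CC1=CC[C@@H]([C@@](C)(O)CCCC(C)(C)NC(=S)N/N=C\c2ccccc2)CC1` gives 60400 nM. Compound 3 `CC1=CC[C@@H]([C@@](C)(O)CCCC(C)(C)NC(=S)N/N=C\c2ccc(O)cc2)CC1` gives 56400 nM.

Compound 3 thus sits among the two real numbers, within the scatter of compound 2, as a 1.1-fold lower number from compound 2 to compound 3 (0.03 log units; within the scatter) shows, while compound 1 stands apart at a limit (the limit of > 100000 nM in this assay, at which 1 of the 3 values shown sits). Compound 4 `CC1=CC[C@@H]([C@@](C)(O)CCCC(C)(C)NC(=S)N/N=C\c2ccccc2Cl)CC1` differs from compound 3 by 2-chlorophenyl in place of 4-hydroxyphenyl on a carbon with a double bond to nitrogen. Within the data shown here, two measured steps bear on this change: an at least 1.6-fold lower number from compound 1 to compound 2 (0.21 log units; that floor lies within the scatter), which only sets a floor, and the step from compound 2 to compound 3, where adding one ring substituent moved nothing beyond the scatter. The new change again only alters the substituent on that ring, so no step beyond the scatter is expected for compound 4, a 1.1-fold lower number from compound 3 to compound 4 (0.05 log units; within the scatter). Compound 4 is therefore estimated at 50000 nM, between 20000 nM and 120000 nM.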

Compound 4, concentration lethal to 50% of the cells: > 100000 nM
Compound 4: no number, only a limit; the forecaster's own chance of this, stated with the estimate: 15%; middle value at least 2.0-fold (0.30 log units) away from the limit.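

Compound 4 shows that carrying a substituted aromatic ring at this carbon does not by itself give a real number, as compounds 2 and 3 might have suggested: compound 4 gives only a limit. The steps are an at least 1.6-fold higher number from compound 2 to compound 4 (0.21 log units; that floor lies within the scatter) and an at least 1.7-fold higher number from compound 3 to compound 4 (0.24 log units; that floor lies within the scatter). Each is only a floor, so the true size of each stays unknown, and compound 4 shares its limit with compound 1: the limit of > 100000 nM in this assay, at which 2 of the 4 values shown sit.

As far as these compounds go, whether an amine or a methoxy group on that ring would give a real number remains open.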